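This account rests on a few compounds, and the source may have more. Where it says the series, first, only, none or still open, it means among the compounds named here.

Measured in a functional assay on MCF7 cells (Homo sapiens) for cytotoxicity, read by MTT assay, with a stated time of 48 h; a lower number here means a stronger inhibitor, a higher number a weaker inhibitor:
Compound 1 `COc1cc(C#N)ccc1OCc1nnc(-c2ccc(F)cc2)o1`: 10300 nM
Compound 2 `COc1ccc(-c2nnc(COc3ccc(C#N)c(F)c3)o2)cc1`: 42200 nM
Compound 3 `COc1ccc(-c2nnc(COc3ccc(-c4nnco4)cc3)o2)cc1`: 31200 nM

Compound 3, at 31200 nM, lies within the usual scatter of compound 2, at 42200 nM. Compound 1 gives a lower number, 10300 nM, and that gap to compound 3 lies beyond the scatter.

The next compound is compound 4 `Fc1ccc(-c2nnc(COc3ccc(-c4nnco4)cc3)o2)cc1`, which has fluoro in place of methoxy on an aromatic carbon, para to a large group (fluoro in place of methoxy on an aromatic carbon). The same difference reads as 4-methoxyphenyl to 4-fluorophenyl. Compound 1, at 10300 nM, also carries 4-fluorophenyl, but it differs from compound 3 elsewhere as well, so it gives only a weak hint. Within the data shown here, no measured pair isolates this change. No step beyond the scatter is therefore expected in this assay. The estimated step is a 1.4-fold lower number from compound 3 to compound 4 (0.15 log units; within the scatter). For compound 4 the expected value is 22000 nM, with an estimated range of 9000 nM to 55000 nM.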

Compound 4, half-maximal inhibitory concentration: 35600 nM
The estimate for compound 4 lay 1.6-fold (0.21 log units) below the measured number; measured number inside the range.
By their numbers in this assay, from the lowest: compound 1; then compounds 3, 4 and 2 (each within the scatter of the next).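

Among these compounds, this is the first pair that isolates the change, and in this assay fluoro in place of methoxy on an aromatic carbon, para to a large group, gives a 1.1-fold higher number from compound 3 to compound 4 (0.06 log units; within the scatter). The position therefore accepts a smaller group with no hydrogen-bond acceptor without any readable shift in the number, and the 4-fluorophenyl group that compound 1 also carries brings no readable change by itself on the core of compound 3. No measurement at hand bears on why the number holds.

The compounds shown leave open whether an amine or a carboxylic acid at this position would move the number beyond the scatter. They also leave open whether the same exchange of methoxy for fluoro would stay as silent on the core of compound 2.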